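Swapping methyl for ethoxy on the shorter-chain compound

The source may report more compounds than this note shows. Statements on the series, on what has been measured and on what is new or still open speak of the compounds shown alone.

In a functional assay on PC-3 cells (Homo sapiens) for cytotoxicity (on this read-out higher numbers stand for weaker inhibition and lower numbers for stronger inhibition), compound 1 `Cc1ccc2nc(NC(=O)CCCCCCC(=O)NO)sc2c1` gives 0.53 ug/mL while compound 2 `Cc1ccc2nc(NC(=O)CCCCC(=O)NO)sc2c1` gives 6.23 ug/mL as the higher, weaker number of the two. For the measured compounds named here, the only measured step of a 12-fold higher number from compound 1 to compound 2 (1.07 log units; beyond the scatter) is large, but it changes the chain and leaves the methyl untouched. Compound 3 `CCOc1ccc2nc(NC(=O)CCCCC(=O)NO)sc2c1` keeps the chain of compound 2 and differs by ethoxy in place of methyl on an aromatic carbon in one swap: ethoxy in place of methyl on an aromatic carbon. Going by the values given here, no measured step tests this swap, so the expected change a 1.0-fold lower number from compound 2 to compound 3 (0.02 log units; within the scatter) in this assay stays within the scatter. For compound 3 the estimate is 6 ug/mL with an expected range of 2.5 ug/mL to 14 ug/mL on this read-out.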

Compound 3, half-maximal inhibitory concentration: 6.69 ug/mL
For compound 3 the middle estimate is 1.1-fold (0.05 log units) below the measured one, and the stated range covers the measured number.
By their numbers in this assay, from the lowest: compound 1; then compounds 2 and 3 (each within the scatter of the next).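

In this assay, ethoxy in place of methyl on this aromatic carbon gives a 1.1-fold higher number from compound 2 to compound 3 (0.03 log units; within the scatter), so the read-out stays within the scatter even though the group entering is larger and brings a hydrogen-bond acceptor. The chain step, a 12-fold higher number from compound 1 to compound 2 (1.07 log units; beyond the scatter), remains the only large step among these compounds, and this first ring change does not match it. No measurement here explains why the swap leaves the number within the scatter.

Going by these compounds, whether an amine or a carboxylic acid on this carbon would also stay within the scatter remains open. So does whether ethoxy would behave the same way on the longer chain of compound 1.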